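The source may hold more compounds than are shown below. What is called first, only, known or untested is meant among the compounds shown, and "the series" means these compounds.

Measured so far:
- compound 1, `CCO[C@@H]1O[C@H](CNC(=O)c2ccc(S(N)(=O)=O)cc2)[C@@H](O)[C@H](O)[C@H]1O`: 1.54 mL/min/kg
- compound 2, `CCO[C@@H]1O[C@H](CNC(=O)c2ccc(S(N)(=O)=O)cc2)[C@@H](O)[C@H](O)[C@H]1N`: 1.56 mL/min/kg

In an ADME assay on microsomes from liver (Mus musculus) for metabolic stability (on this read-out lower numbers stand for slow clearance and higher numbers for fast clearance), compound 1 gives 1.54 mL/min/kg and compound 2 gives 1.56 mL/min/kg. For the measured compounds named here, the only measured step, a 1.0-fold higher number from compound 1 to compound 2 (0.01 log units; within the scatter), comes from putting amino in place of hydroxy on a saturated ring carbon, and the two numbers sit within the scatter of each other, so nothing separates compound 2 from compound 1 on this read-out.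

Compound 3, `CCCO[C@@H]1O[C@H](CNC(=O)c2ccc(S(N)(=O)=O)cc2)[C@@H](O)[C@H](O)[C@H]1N`, differs from compound 2 by methyl in place of hydrogen on a saturated chain carbon, two bonds along the chain from an oxygen on a saturated carbon. Cut one bond further out, this reads as ethoxy to propoxy. Going by the values given here, no measured step of this kind exists here; the one known step concerns a different part of the shared core, and it was within the scatter. There is therefore no basis for expecting a step beyond the scatter in this assay in either direction, and the expected step is a 1.0-fold higher number from compound 2 to compound 3 (0.01 log units; within the scatter).

Compound 3 is expected to give 1.6 mL/min/kg. For compound 3 the estimated range runs from 0.8 mL/min/kg to 3.2 mL/min/kg.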

Compound 3, clearance: 1.42 mL/min/kg
Compound 3: the middle estimate sits 1.1-fold (0.05 log units) above what was measured; low and high end bracket the measured number.
By their numbers in this assay, from the lowest: compounds 3, 1 and 2 (each within the scatter of the next).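

In this assay, extending the chain from ethoxy to propoxy gives a 1.1-fold lower number from compound 2 to compound 3 (0.04 log units; within the scatter), so a methyl group in place of hydrogen at this position, two bonds along the chain from an oxygen on a saturated carbon, leaves the read-out unchanged within the scatter. This is the first measured step at this end of the molecule, and with a 1.0-fold higher number from compound 1 to compound 2 (0.01 log units; within the scatter) at another part of the shared core, both single changes shown so far stay within the scatter, though two steps are too few to support a wider rule. Nothing measured here explains why the added methyl leaves the number unchanged.

Still open, going by these compounds, is whether that holds for a longer chain such as butoxy, a branched one such as isopropoxy, or a ring-bearing one such as benzyloxy, any of which could show where this position stops being indifferent. Also open, on these data alone, is whether ethoxy to propoxy reads the same when hydroxy rather than amino sits on the ring carbon, and how a larger group such as acetamido would read at that carbon.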